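Swapping phenoxy for 3,5-dimethylbenzyl on the fused ring

A few compounds are considered here, and "the series" means these few. Any claim that something is new, unique, unknown or untested is made for them only; others in the source may bear on it.

Measured compounds:
compound 1 `c1ccc(Oc2ccc3c(NCCCNCc4ccco4)ccnc3c2)cc1`: 9.28
compound 2 `COc1cccc(CNCCCNc2ccnc3cc(Oc4ccccc4)ccc23)c1O`: 9.28
compound 3 `COc1ccc(F)cc1CNCCCNc1ccnc2cc(-c3ccc(C(C)(C)C)cc3)ccc12`: 9.47

In a physicochemical assay for acid dissociation, compound 2 gives 9.28, level with compound 1 at the digits shown; together the two are the lowest of the three numbers, and compound 3 sits higher by an amount that is within the scatter. Going by the values given here, the one measured step, no change at the digits printed from compound 1 to compound 2 (within the scatter), replaces one group on the saturated chain carbon bound to the amine nitrogen and leaves the read-out unchanged.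

Compound 4 `COc1cccc(CNCCCNc2ccnc3cc(Cc4cc(C)cc(C)c4)ccc23)c1O` has not been measured. It differs from compound 2 in one place: 3,5-dimethylbenzyl in place of phenoxy on an aromatic carbon. Among the compounds with values here, no measured step changes a group on this fused ring system, so nothing directly bears on it. The step from compound 1 to compound 2 and the gap to compound 3 both show that the three numbers cluster, while the chain and its amine nitrogens are untouched in compound 4. A step of a number 0.07 log units higher from compound 2 to compound 4 (within the scatter) is therefore expected, none beyond the scatter. For compound 4 the estimate is 9.35, between 9 and 9.7.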

Compound 4, acid dissociation constant: 9.47
Estimate against measurement, compound 4: 0.12 log units below; low and high end bracket the measured number.
By their numbers in this assay, from the lowest: compounds 1, 2, 3 and 4 (each within the scatter of the next).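

This is the only step shown that changes a group on an aromatic carbon of the shared core, and in this assay the exchange of phenoxy for 3,5-dimethylbenzyl amounts to a number 0.19 log units higher from compound 2 to compound 4 (within the scatter). Going by these compounds alone, the read-out therefore stays within the scatter when a group with a hydrogen-bond acceptor gives way to one made of carbon only, which the earlier compounds, with no single change at this position, could not show. No evidence bearing on this result is available, so nothing can be said about what lies behind it.

The compounds shown leave open whether an amine or a carboxylic acid on this aromatic carbon would also stay within the scatter. They also leave open whether a longer chain carrying the two amine nitrogens would alter the read-out.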